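Trimming an Ethyl to a Methyl on the Phenyl Ring

The source may hold more compounds than are shown below. What is called first, only, known or untested is meant among the compounds shown, and "the series" means these compounds.

Compound 3 `CCc1ccc(N2C(=O)NC3(CSC4=C3C(=O)c3ncccc3C4=O)C2=O)cc1` sits second highest of the three numbers in a functional assay on MCF7 cells (Homo sapiens) for antiproliferative activity, read by MTT assay, with a stated time of 96 h (on this read-out higher numbers stand for weaker inhibition and lower numbers for stronger inhibition), where compound 3 gives 50 nM. The unsubstituted parent compound 1 `O=C1NC(=O)C2(CSC3=C2C(=O)c2ncccc2C3=O)N1` gives 120 nM in this assay, and compound 2 `O=C1C2=C(C(=O)c3ncccc31)C1(CS2)NC(=O)N(c2ccccc2)C1=O`, which carries a plain phenyl on the ring nitrogen, gives 1 nM. The step of a 120-fold lower number from compound 1 to compound 2 (2.08 log units; beyond the scatter) was large, while a 2.4-fold lower number from compound 1 to compound 3 (0.38 log units; beyond the scatter) was only modest, so the ethyl on the phenyl ring costs most of what the phenyl gained: a 50-fold higher number from compound 2 to compound 3 (1.70 log units; beyond the scatter).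

Compound 4 `Cc1ccc(N2C(=O)NC3(CSC4=C3C(=O)c3ncccc3C4=O)C2=O)cc1` differs from compound 3 by hydrogen in place of methyl on a saturated chain carbon bound to an aromatic carbon. The step that bears on this is a 50-fold higher number from compound 2 to compound 3 (1.70 log units; beyond the scatter), since compound 4 keeps part of that ethyl. Compound 4 is therefore expected to move part of the way back toward compound 2, that is a lower number beyond the scatter, a 5.0-fold lower number from compound 3 to compound 4 (0.70 log units; beyond the scatter). In this assay compound 4 is estimated at 10 nM, with a range from 2 nM to 40 nM.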

Compound 4, half-maximal inhibitory concentration: 2 nM
Compound 4: middle estimate off by 5.0-fold (0.70 log units), on the high side, and the stated range covers the measured number.
By their numbers in this assay, from the lowest: compounds 2 and 4 (each within the scatter of the next); then compound 3; then compound 1.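

In this assay, within the data shown here, the single carbon that leaves at this place carries a large effect: hydrogen in place of methyl on a saturated chain carbon bound to an aromatic carbon gives a 25-fold lower number from compound 3 to compound 4 (1.40 log units; beyond the scatter), although only one heavy atom changes. Among these compounds, the 4-methylphenyl group also stands well apart from the unsubstituted parent, with a 60-fold lower number from compound 1 to compound 4 (1.78 log units; beyond the scatter), while methyl in place of hydrogen on an aromatic carbon gives a 2.0-fold higher number from compound 2 to compound 4 (0.30 log units; within the scatter), so that of the three aryl compounds only the one with the ethyl stands apart. Nothing at hand accounts for the sharp difference between the ethyl and the methyl.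

The compounds shown leave open whether a longer chain such as propyl at this place would follow the ethyl. They also leave open whether a methoxy group or a chlorine atom there would follow the methyl or the ethyl.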